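Ethyl Ester in Place of the Acid in Rats

The source may report more compounds than this note shows. Statements on the series, on what has been measured and on what is new or still open speak of the compounds shown alone.

Compound 1 `O=C(O)c1cnc(-c2ccc(Cl)cc2)[nH]c1=O` gives 5 mg/kg in a functional assay on the whole organism (strain Sprague-Dawley) for inhibition, with Rattus norvegicus as the target, with a stated time of 10 min; on this read-out higher numbers stand for an effect only at larger amounts of compound and lower numbers for an effect already at smaller amounts.
Compound 2 `CC1Cc2cccc(-c3ncc(C(=O)O)c(=O)[nH]3)c2O1` gives 5 mg/kg in this assay.
Compound 3 `CCOC(=O)c1cnc(-c2ccc(Cl)cc2)[nH]c1=O` gives > 30 mg/kg in this assay, and that value is a limit of the assay rather than a number.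

Compound 1 and compound 2 carry different cores; the difference between the two cores is not broken down here. Their two values sit level within the usual scatter. The change ethyl in place of hydrogen on an oxygen next to a carbonyl group produced an at least 6.0-fold higher number from compound 1 to compound 3 (0.77 log units; beyond the scatter), a step that rests on (the limit of > 30 mg/kg in this assay, at which 1 of the 3 values shown sits). Compound 4 `CCOC(=O)c1cnc(-c2cccc3c2OC(C)C3)[nH]c1=O` carries the same change from compound 2, namely (ethyl in place of hydrogen on an oxygen next to a carbonyl group). The same loss is expected here, so that the step of an 8.0-fold higher number from compound 2 to compound 4 (0.90 log units; beyond the scatter) is estimated, because an at least 6.0-fold higher number from compound 1 to compound 3 (0.77 log units; beyond the scatter). Compound 4 is therefore expected to give about 40 mg/kg, with 15 mg/kg to 150 mg/kg as the likely range, and a limit rather than a number is the more likely report.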

Compound 4, dose for 50% inhibition: 5 mg/kg
Estimate against measurement, compound 4: 8.0-fold (0.90 log units) above, outside the stated range (below it).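

Ethyl in place of hydrogen on an oxygen next to a carbonyl group gives no change at the digits printed from compound 2 to compound 4 (within the scatter) in this assay. The same change therefore does not carry over from one core to the other with the same size: the same change on two cores in this assay, an at least 6.0-fold higher number (0.77 log units; beyond the scatter) from compound 1 to compound 3 and no change at the digits printed (within the scatter) from compound 2 to compound 4, at least 6.0-fold (0.77 log units) apart, beyond the scatter of two such steps These two pairs show that the outcome of this change can differ with the core, but they do not show why, or which of the two outcomes would be the more usual one in this series.

The compounds shown leave open whether a third core would follow compound 1 or compound 2. They also leave open how a longer chain such as butyl, or an amide in place of the ester, would behave on either core.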